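The source may report more compounds than this note shows. Statements on the series, on what has been measured and on what is new or still open speak of the compounds shown alone.

Measured so far:
compound 1 `O=C1/C(=C\c2cc3ccccc3nc2Cl)c2ccccc2N1c1c(Cl)cccc1Cl` — 5 ug/mL
compound 2 `O=C1/C(=C\c2ccc(F)cc2)c2ccccc2N1c1c(Cl)cccc1Cl` — 5 ug/mL

In a functional assay on MIA PaCa-2 cells (Homo sapiens) for cytotoxicity, read by MTT assay, with a stated time of 72 h (on this read-out higher numbers stand for an effect only at larger amounts of compound and lower numbers for an effect already at smaller amounts), compound 1 gives 5 ug/mL. In the same read-out compound 2 gives 5 ug/mL. Compound 2 therefore stands level with compound 1 at the digits shown; the two values lie within the scatter, so they cannot be told apart. For the measured compounds named here, no two measured compounds differ in a single place, so no step of one change has yet been measured.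

Compound 3 `O=C1/C(=C\c2ccccc2Cl)c2ccccc2N1c1c(Cl)cccc1Cl` has not been measured. It follows from compound 2 by 2-chlorophenyl in place of 4-fluorophenyl on a double-bonded chain carbon bound to a double-bonded ring carbon. The two measured compounds carry rather different groups at that place and give the same value, so the step of no change at the digits printed from compound 2 to compound 3 (within the scatter) is expected to stay within the scatter, with no direction to be called. Compound 3 is accordingly expected to give about 5 ug/mL, with a range from 2.5 ug/mL to 10 ug/mL.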

Compound 3, concentration for half-maximal effect: > 100 ug/mL
Compound 3 ended at the assay's limit; the forecaster's own chance of this, stated with the estimate: 5%; at least 20-fold (1.30 log units) between middle value and limit.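

At this place the group decides the outcome: in this assay, 2-chlorophenyl in place of 4-fluorophenyl on a double-bonded chain carbon bound to a double-bonded ring carbon gives an at least 20-fold higher number from compound 2 to compound 3 (1.30 log units; beyond the scatter). Compound 1 and compound 2 alone showed no difference at this place, so its sensitivity to the change appears only with compound 3. The value of compound 3 is a limit and not a number, so the step gives only a lower bound on the change: the limit of > 100 ug/mL in this assay, at which 1 of the 3 values shown sits.

The single step changes both the halogen and where it sits on the phenyl ring, and the compounds shown do not separate the two. From the compounds shown here alone, how a plain phenyl group, or a phenyl group carrying an amine or a carboxylic acid, would read at this place also stays open.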